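A Fluorine Added to a Potent Urea

The source may report more compounds than this note shows. Statements on the series, on what has been measured and on what is new or still open speak of the compounds shown alone.

Among the compounds with values here, compound 2 `COc1ccc(-c2cnc3nc(N)nc(N4CCN(C(=O)Nc5ccccc5)CC4)c3n2)cc1OC` gives the lowest of the two numbers known in a functional assay on cells (T-cell, Homo sapiens) for inhibition (a lower number here means a stronger inhibitor, a higher number a weaker inhibitor), measuring 3.4 nM. Compound 1 `COc1ccc(-c2cnc3nc(N)nc(N4CCN(Cc5ccccc5)CC4)c3n2)cc1OC` gives 900 nM in this assay. Within the data shown here, the only measured step is a 260-fold lower number from compound 1 to compound 2 (2.42 log units; beyond the scatter), and it concerns a different part of the molecule. Compound 3 `COc1ccc(-c2cnc3nc(N)nc(N4CCN(C(=O)Nc5ccc(F)cc5)CC4)c3n2)cc1OC` differs from compound 2 by fluoro in place of hydrogen on an aromatic carbon. Among the measured compounds shown here, no measured step bears on this small change, so nothing beyond the scatter is expected in this assay. Compound 3 is therefore estimated at 3.5 nM, within 1.2 nM to 11 nM, which means an expected step of a 1.0-fold higher number from compound 2 to compound 3 (0.01 log units; within the scatter).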

Compound 3, half-maximal inhibitory concentration: 7 nM
The estimate for compound 3 lay 2.0-fold (0.30 log units) below the measured number, within the range that was stated.
By their numbers in this assay, from the lowest: compound 2; then compound 3; then compound 1.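

Fluoro on this aromatic carbon, para to a large group, is not a silent change in this assay: it gives a 2.1-fold higher number from compound 2 to compound 3 (0.31 log units; beyond the scatter), a modest loss but one beyond the scatter. The loss is small beside the difference from the benzyl compound, seen in a 130-fold lower number from compound 1 to compound 3 (2.11 log units; beyond the scatter), so the (4-fluorophenyl)carbamoyl group keeps most of the advantage of phenylcarbamoyl. No supporting data are available to explain the effect of the fluoro. Still open, as far as these compounds go, is whether a chloro, a methyl or an amine on this same carbon would give a similar number, or a lower one.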